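This account rests on a few compounds, and the source may have more. Where it says the series, first, only, none or still open, it means among the compounds named here.

Three compounds share one core and differ only in the group attached to the thiocarbonyl nitrogen. Compound 1 `CC(C)NC(=S)N/N=C\c1c[nH]c2ccccc12` carries an isopropylamino group there. In an ADME assay on KB cells (Homo sapiens) for cytotoxicity, read by MTT assay, with a stated time of 44 h (a higher number here means a weaker inhibitor, a lower number a stronger inhibitor), compound 1 reaches only the limit of the assay, > 100000 nM, and no number. Compound 2 `CCN(CC)C(=S)N/N=C\c1c[nH]c2ccccc12` has a diethylamino group in that place. In this assay compound 2 likewise gives only the limit > 100000 nM. Compound 3 `Cc1ccccc1NC(=S)N/N=C\c1c[nH]c2ccccc12` bears a 2-methylphenyl group on the amide-type nitrogen. In this assay compound 3 also stops at the limit, > 100000 nM. Compound 3 thus stands exactly where both companions stand, since all three sit at the limit of > 100000 nM in this assay, at which 3 of the 3 values shown sit.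

Compound 4 `CC(C)CNC(=S)N/N=C\c1c[nH]c2ccccc12` is the next variation at that same nitrogen: isobutyl in place of 2-methylphenyl on an amide-type nitrogen. The step that bears on it most directly is a step that the two limits leave unreadable from compound 1 to compound 3, which exchanges a small alkyl group for the same aryl group in the reverse sense; the other known step, a step that the two limits leave unreadable from compound 1 to compound 2, is equally unreadable. No direction beyond the scatter can be drawn from them, and compound 4 is expected to sit with its companions, with an estimated step that the limit leaves unreadable from compound 3 to compound 4. The estimate for compound 4 in this assay is 150000 nM, within a range from 40000 nM to 600000 nM.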

Compound 4, half-maximal inhibitory concentration: > 100000 nM
Compound 4: only a limit was reported; the forecaster's own chance of this, stated with the estimate: 80%; the middle value lies beyond the limit too.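

In this assay, among the compounds shown here, compound 4 gives only a limit, > 100000 nM, so no step linking compound 4 with compound 1, compound 2 or compound 3 can be read. The compounds shown leave open whether any group on this nitrogen would give a readable value, because all four stop at the same point: the limit of > 100000 nM in this assay, at which 4 of the 4 values shown sit.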